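Sulfonamide series: aryl swap on the sulfonamide nitrogen

The source may hold more compounds than are shown below. What is called first, only, known or untested is meant among the compounds shown, and "the series" means these compounds.

Three compounds have numbers in an assay on isolated protein for inhibition of Nicotinamide phosphoribosyltransferase (Homo sapiens), read by WST assay, with stated times of 60 min, 5 min and 30 min, in the presence of a further agent that is not named here; a lower number here means a stronger inhibitor, a higher number a weaker inhibitor. Compound 1 `O=C(/C=C/c1cccnc1)NCCCCCc1ccc(S(=O)(=O)Nc2ccccc2)cc1` gives 28.4 nM. Compound 2 `O=C(/C=C/c1cccnc1)NCCCCCCc1ccc(S(=O)(=O)Nc2ccccc2)cc1` gives 14.4 nM. Compound 3 `Cc1ccccc1NS(=O)(=O)c1cccc(CCCCCCNC(=O)/C=C/c2cccnc2)c1` gives 5.08 nM, the lowest of the three numbers; compound 2 is nearest, with a higher number beyond the scatter, and compound 1 is furthest, also beyond the scatter. For the measured compounds named here, no two measured compounds differ in one place, so no single step is available. Compound 4 `O=C(/C=C/c1cccnc1)NCCCCCCc1cccc(S(=O)(=O)Nc2ccc(Cl)cc2)c1` differs from compound 3 by 4-chlorophenyl in place of 2-methylphenyl on a sulfonamide nitrogen. Going by the values given here, no step of this kind exists among the measured compounds, so the expectation is loose. The step of a 1.6-fold higher number from compound 3 to compound 4 (0.20 log units; within the scatter) is expected to stay within the scatter or only a little beyond it toward a higher number. In this assay compound 4 is estimated at 8 nM, within 2.5 nM to 25 nM.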

Compound 4, half-maximal inhibitory concentration: 10.8 nM
For compound 4 the middle estimate is 1.4-fold (0.13 log units) below the measured one; the range from low to high includes it.
By their numbers in this assay, from the lowest: compound 3; then compounds 4, 2 and 1 (each within the scatter of the next, the first and the last beyond it).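

In this assay, for the compounds shown here, 4-chlorophenyl in place of 2-methylphenyl on a sulfonamide nitrogen gives a 2.1-fold higher number from compound 3 to compound 4 (0.33 log units; beyond the scatter), the first step that changes only one place. This position therefore accepts an exchange of one substituted phenyl for another with only a modest step. Nothing available explains the direction of this step.

A single step cannot separate the effect of swapping methyl for chlorine from that of moving the substituent on the ring. On these data alone, how a methoxy group, an amine or a carboxylic acid on that phenyl ring would read remains open.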